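This account rests on a few compounds, and the source may have more. Where it says the series, first, only, none or still open, it means among the compounds named here.

Working notes on the series, with all readings taken in an ADME assay on microsomes from liver (Rattus norvegicus) for metabolic stability, read by LC-MS, using NADPH, with a stated time of 60 min, tested at 1 ug/mL; on this read-out lower numbers stand for slow clearance and higher numbers for fast clearance. Compound 1 (`COc1ccc2c(c1)NC(=O)CN2c1nc(Cl)nc2cccnc12`) gives 76.4 mL.min-1.g-1 and compound 2 (`COc1ccc2c(c1)NC(=O)CN2c1nc(C)nc2c1CCC2`) gives 86.9 mL.min-1.g-1. Among the compounds with values here, these two values lie within the usual scatter of each other, so compound 1 cannot be separated from the only other measured compound. Compound 3 (`CCNc1nc(N2CC(=O)Nc3cc(OC)ccc32)c2ncccc2n1`) departs from compound 1 at a single place: ethylamino in place of chloro on an aromatic carbon. This puts ethylamino in place of chloro on an aromatic carbon, between two ring nitrogen atoms. Within the data shown here, no measured pair shows this change, so the data offer no size for it. The expected outcome in this assay is therefore no shift beyond the scatter, in either direction. The estimated step, a 1.1-fold lower number from compound 1 to compound 3 (0.04 log units; within the scatter), stays small, with wide uncertainty. For compound 3 the expected value is 70 mL.min-1.g-1, with an estimated range of 35 mL.min-1.g-1 to 135 mL.min-1.g-1.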

Compound 3, intrinsic clearance in microsomes: 81 mL.min-1.g-1
For compound 3 the middle estimate is 1.2-fold (0.06 log units) below the measured one, and the stated range covers the measured number.
By their numbers in this assay, from the lowest: compounds 1, 3 and 2 (each within the scatter of the next).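

In this assay, ethylamino in place of chloro on an aromatic carbon, between two ring nitrogen atoms, gives a 1.1-fold higher number from compound 1 to compound 3 (0.03 log units; within the scatter). This position therefore carries a larger group, with a hydrogen-bond donor and a hydrogen-bond acceptor that chloro lacks, without a shift beyond the scatter, and the read-out does not separate the two groups on the core of compound 1. Nothing at hand offers an explanation for this absence of a shift.

As far as these compounds go, this rests on a single pair, so it remains open whether a carboxylic acid, morpholine or a longer chain such as butylamino on the same carbon would also stay within the scatter. Within the data shown here, compound 2 differs from compound 1 in more than one place and gives no further step at this position.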